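Iodo for Isopropyl on the Aryl Sulfonate Ester

This account rests on a few compounds, and the source may have more. Where it says the series, first, only, none or still open, it means among the compounds named here.

Measured so far:
compound 1, `O=C(Nc1ccc(S(=O)(=O)Oc2ccccc2I)cc1)NC1CC1` — 7400 nM
compound 2, `CC(C)c1ccccc1OS(=O)(=O)c1ccc(NC(=O)NCC2CCCC2)cc1` — 7100 nM

Of the compounds shown here, two share a sulfonate-linked urea scaffold and have been tested in a functional assay on MCF7 cells (Homo sapiens) for antiproliferative activity, read by sulforhodamine B assay, with a stated time of 48 h; a higher number here means a weaker inhibitor, a lower number a stronger inhibitor. Compound 1 gives 7400 nM in this assay. Compound 2 gives 7100 nM in this assay, the lowest of the two numbers, yet compound 1 sits so close to it that the two values fall within the usual scatter and no order between them can be read.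

Compound 3, `O=C(NCC1CCCC1)Nc1ccc(S(=O)(=O)Oc2ccccc2I)cc1`, has not been measured. It differs from compound 2 in one place: iodo in place of isopropyl on an aromatic carbon. Among the compounds with values here, the same iodophenyl end is present in compound 1, which carries a different urea substituent, so no pair of measured compounds isolates this change on its own. With both measured values so near each other, nothing in the data points to a step in either direction beyond the scatter.

For compound 3 the expected value in this assay is 7000 nM, with a range from 3500 nM to 14000 nM. This estimate means a step of a 1.0-fold lower number from compound 2 to compound 3 (0.01 log units; within the scatter), which is expected to stay within the scatter.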

Compound 3, half-maximal inhibitory concentration: 6600 nM
Beside the measured number, compound 3's estimate is 1.1-fold (0.03 log units) above it; the range from low to high includes it.
By their numbers in this assay, from the lowest: compounds 3, 2 and 1 (each within the scatter of the next).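

Within the data shown here, compound 3 gives the first direct reading of iodo in place of isopropyl on an aromatic carbon with the rest of the structure held fixed: in this assay the exchange amounts to a 1.1-fold lower number from compound 2 to compound 3 (0.03 log units; within the scatter), so the 2-isopropylphenyl and 2-iodophenyl ends cannot be told apart here. It also gives a direct reading of cyclopentylmethyl in place of cyclopropyl on an amide-type nitrogen with the 2-iodophenyl end held fixed, and this exchange amounts to a 1.1-fold lower number from compound 1 to compound 3 (0.05 log units; within the scatter), so neither single change separates the compounds. No measurement shown here accounts for how close these numbers lie.

Iodo and isopropyl are the only groups shown at this place on the ring, so it remains open whether a methoxy group, an amine or a carboxylic acid there would move the number beyond the scatter. On the amide-type nitrogen only cyclopropyl and cyclopentylmethyl are shown, which leaves open what a longer chain or a chain ending in a hydroxyl group would do.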